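This account rests on a few compounds, and the source may have more. Where it says the series, first, only, none or still open, it means among the compounds named here.

Compound 1 (`Nc1nc(OCc2ccccc2)c2ncn(/C=C3/CC3(CO)CO)c2n1`) and compound 2 (`Nc1nc(N2CCCC2)c2ncn(/C=C3/CC3(CO)CO)c2n1`) share one core and differ in a single group. In an ADME assay on HFF cells (Homo sapiens) for cytotoxicity, with a stated time of 8 days (a higher number here means that more compound is tolerated, a lower number that less compound is tolerated), compound 1 gives only a limit of the assay (> 300000 nM). Compound 2 also gives only a limit (> 300000 nM), so where it stands is known without an exact number. Both compounds sit at the same limit (the limit of > 300000 nM in this assay, at which 2 of the 2 values shown sit). Among the measured compounds shown here, the one measured step is a step that the two limits leave unreadable from compound 1 to compound 2 and it brings pyrrolidin-1-yl in place of benzyloxy on an aromatic carbon. That step offers no size to carry forward.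

Compound 3 (`CCCCCCCCSc1nc(N)nc2c1ncn2/C=C1/CC1(CO)CO`) has octylsulfanyl in place of pyrrolidin-1-yl on an aromatic carbon. For the measured compounds named here, this open chain has no counterpart in compound 1 or compound 2, so the expectation rests on little. A moderate move in this assay towards less compound tolerated is expected, and a result at the same limit remains quite possible. The estimated change is an at least 3.0-fold lower number from compound 2 to compound 3 (0.47 log units; beyond the scatter) and it is no more than an expectation. Compound 3 is estimated at 100000 nM with an expected range from 20000 nM to 300000 nM in this assay when a number is obtained.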

Compound 3, half-maximal cytotoxic concentration: > 300000 nM
Compound 3 gave a limit, no number; the forecaster's own chance of this, stated with the estimate: 45%; middle value at least 3.0-fold (0.47 log units) away from the limit.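

Compound 3 also gives only a limit in this assay, so no new step can be read between compound 1, compound 2 and compound 3, and none of these steps has a readable size. All three compounds sit at one limit: the limit of > 300000 nM in this assay, at which 3 of the 3 values shown sit.

The compounds shown leave open how far any of these three groups separates the compounds in cytotoxicity, since none has yielded an exact number.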